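A few compounds are considered here, and "the series" means these few. Any claim that something is new, unique, unknown or untested is made for them only; others in the source may bear on it.

Measured in a functional assay on the whole organism (Tail, strain ICR) with Mus musculus as the target, in the tail flick test, with a stated time of 120 min, at a dose of 25 umol/kg by the oral route; on this read-out higher numbers stand for a stronger effect at the one dose given and lower numbers for a weaker effect:
compound 1 `O=C(CN(c1nc(Cl)nc2[nH]cnc12)C1CC1)NCC(=O)OCc1ccccc1` gives 21.7%;
compound 2 `N=C(N)NCCC[C@H](NC(=O)CN(c1nc(Cl)nc2[nH]cnc12)C1CC1)C(=O)OCc1ccccc1` gives 10.2%;
compound 3 `O=C(CN(c1nc(Cl)nc2[nH]cnc12)C1CC1)N[C@@H](CCC(=O)OCc1ccccc1)C(=O)OCc1ccccc1` gives 45.9%.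

Compound 3 stands highest of the three: a number 24.2 percentage points higher from compound 1 to compound 3 (beyond the scatter) and a number 35.7 percentage points higher from compound 2 to compound 3 (beyond the scatter), both beyond the scatter. Compound 4 `CC(C)C[C@H](NC(=O)CN(c1nc(Cl)nc2[nH]cnc12)C1CC1)C(=O)OCc1ccccc1` differs from compound 3 by isopropyl in place of (benzyloxycarbonyl)methyl on a saturated chain carbon, two bonds along the chain from an amide-type nitrogen and a carbonyl carbon. Both measured steps ending at compound 3 bear on this change, as each altered the group on the same saturated chain carbon; the modest one added 2-(benzyloxycarbonyl)ethyl where compound 1 carried hydrogen, the large one exchanged the guanidine-bearing chain of compound 2 for it. With that arm now leaving and isobutyl entering, a modest downward step is expected, a number 15.9 percentage points lower from compound 3 to compound 4 (beyond the scatter). Compound 4 is estimated at 30%, within 15% to 47%.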

Compound 4, a percentage reported as activity, at one dose (the size of the read-out at that dose, not a potency): 8.58%
For compound 4 the middle estimate is 21.4 percentage points above the measured one; the whole stated range lies above it.
By their numbers in this assay, from the lowest: compounds 4 and 2 (each within the scatter of the next); then compound 1; then compound 3.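

Swapping 2-(benzyloxycarbonyl)ethyl for isobutyl on this saturated chain carbon removes most of the effect seen with compound 3 (a number 37.3 percentage points lower from compound 3 to compound 4 (beyond the scatter)), so a plain branched chain cannot stand in for that arm. Isobutyl also does worse here than the hydrogen of compound 1 (a number 13.1 percentage points lower from compound 1 to compound 4 (beyond the scatter)), and it cannot be told apart from the guanidine-bearing chain (a number 1.6 percentage points lower from compound 2 to compound 4 (within the scatter)). No measurement at hand explains these steps.

Still open, as far as these compounds go, is whether the arm's benzyl ester is needed, or whether a free carboxylic acid or a longer chain without an ester would serve equally well on this carbon.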